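Ring Closure at the Acid-Bearing Carbon of Compound 2

The source may report more compounds than this note shows. Statements on the series, on what has been measured and on what is new or still open speak of the compounds shown alone.

Of the compounds shown here, three have been measured in a functional assay on CHO cells for antagonist activity at sphingosine 1-phosphate receptor 2 (Homo sapiens), read by calcium flux; a higher number here means a weaker inhibitor, a lower number a stronger inhibitor. Compound 1 `O=C(O)Cn1nc(CC(=O)Nc2ccc(OC(F)(F)F)c(Cl)c2)c2ccccc2c1=O` gives 389 nM in this assay. Compound 2 `CCC(C(=O)O)c1nn(Cc2cn3cc(OCC4CC4)c(Cl)cc3n2)c2ccccc2c1=O` gives 5.6 nM in this assay, the lowest of the three numbers. Compound 3 `CCOc1cc2[nH]c(Cc3nn(CC(=O)N4CCOCC4)c(=O)c4ccccc34)nc2cc1Cl` gives 10 nM in this assay; the gap between compound 3 and compound 2 lies within the scatter, so no order between them can be claimed, whereas the gap between compound 1 and compound 2 lies beyond the scatter. Within the data shown here, no two of these measured compounds differ in a single place, so no measured step exists to lean on.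

Compound 4 `O=C(O)C1(c2nn(Cc3cn4cc(OCC5CC5)c(Cl)cc4n3)c3ccccc3c2=O)CC1` differs from compound 2 in one place: 1-carboxycyclopropyl in place of 1-carboxypropyl on an aromatic carbon. The leaving group and the entering group are alike in what is counted; the entering group is distinguished by its three-membered ring of carbon only. Among the measured compounds shown here, with no measured step of this kind available, the step from compound 2 to compound 4 is expected to be small, in either direction, and to stay within the scatter, a 1.3-fold higher number from compound 2 to compound 4 (0.10 log units; within the scatter). Compound 4 is therefore estimated at 7 nM in this assay, with a range from 2 nM to 25 nM.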

Compound 4, half-maximal inhibitory concentration: 16 nM
For compound 4 the middle estimate is 2.3-fold (0.36 log units) below the measured one; low and high end bracket the measured number.
By their numbers in this assay, from the lowest: compounds 2, 3 and 4 (each within the scatter of the next, the first and the last beyond it); then compound 1.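

Closing the acid-bearing carbon into a ring gives the first step in this series that can be read at a single place: in this assay, 1-carboxycyclopropyl in place of 1-carboxypropyl gives a 2.9-fold higher number from compound 2 to compound 4 (0.46 log units; beyond the scatter), a modest loss of inhibition. The two groups match in everything counted, including heavy atoms, double bonds, hydrogen-bond donors and acceptors, and net charge, and differ only in the three-membered ring of carbon only, so this position on the aromatic carbon, next to the ring nitrogen, registers a change that those counts do not capture. Nothing measured here accounts for the size or direction of this step.

The compounds shown leave open whether the step belongs to the three-membered ring in particular or to ring closure at this carbon in general, as a 1-carboxycyclobutyl group would help to show. They also leave open how an open-chain group with a shorter branch, such as 1-carboxyethyl, or a tetrazole in place of the carboxylic acid, would read at this same position.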